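Nitro in Place of Chloro on a Monoterpene-Derived Ester Core

The source may hold more compounds than are shown below. What is called first, only, known or untested is meant among the compounds shown, and "the series" means these compounds.

Measured so far:
- Compound 1 `CC1=CC[C@H](C(C)C)c2cc(C)c(OC(=O)c3cccc(C(F)(F)F)c3)cc21`: in a functional assay on K562 cells (Homo sapiens) for antiproliferative activity, read by sulforhodamine B assay, with a stated time of 48 h, tested at 50 uM (on this read-out lower numbers stand for less inhibition and higher numbers for more inhibition at the one concentration tested (going by the name of the read-out)), compound 1 gives 45.5%.
- Compound 2 `CC1=CC[C@H](C(C)C)c2cc(C)c(OC(=O)c3cccc(Cl)c3)cc21`: in this assay compound 2 is reported as "not active" (no number reported).

The two measured compounds share one core and differ only in the group on the aromatic ring of the side chain. Compound 1, with a trifluoromethyl group, reaches a moderate value, while compound 2, carrying chloro, has no single number: it is recorded only as not active, so its standing on the scale cannot be placed exactly, beyond being low.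

Compound 3 `CC1=CC[C@H](C(C)C)c2cc(C)c(OC(=O)c3cccc([N+](=O)[O-])c3)cc21` is the next step from compound 2. The change is nitro in place of chloro on an aromatic carbon. Going by the values given here, no measured pair of this kind is available, so the size of the step is open. A shift upward from the level of compound 2 is plausible, but without a measured step it may also stay within the scatter.

Compound 3 is expected to give about 25% in this assay, in a range from 0% to 55%.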

Compound 3, a percentage reported as inhibition, at one concentration (the size of the read-out at that concentration, not a potency): 15.9%
Compound 3: middle estimate off by 9.1 percentage points, on the high side, and the stated range covers the measured number.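

In this assay, nitro in place of trifluoromethyl on the same aromatic carbon gives a number 29.6 percentage points lower from compound 1 to compound 3 (beyond the scatter), so the read-out at this place depends on which of these two groups is present. Compound 3 still has a number, 15.9%, whereas compound 2 is recorded only as not active, so the step from 3-chlorophenyl to 3-nitrophenyl cannot be read. Nothing available explains why the read-out differs between these groups.

The compounds shown leave open how an amine or a carboxylic acid on this aromatic carbon would read in this assay. They also leave open whether trifluoromethyl would keep its higher value over nitro if either group were moved elsewhere on the ring.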